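A few compounds are considered here, and "the series" means these few. Any claim that something is new, unique, unknown or untested is made for them only; others in the source may bear on it.

In a functional assay on HepG2 cells (Homo sapiens) for inhibition, read by MTT assay (a higher number here means a weaker inhibitor, a lower number a stronger inhibitor), the measured compounds are:
compound 1 `COc1cc2ncnc(Nc3ccc(NC(=O)c4ccccc4F)cc3)c2cc1OC` at 13000 nM
compound 2 `COc1cc2ncnc(Nc3ccc(NC(=O)c4cccc(I)c4)cc3)c2cc1OC` at 28000 nM

Compound 2 carries the higher of the two numbers and is the weaker inhibitor of the pair. Next comes compound 3 `COc1cc2ncnc(Nc3ccc(NC(=O)c4ccc(Cl)c(Cl)c4)cc3)c2cc1OC` with the difference 3,4-dichlorophenyl in place of 3-iodophenyl on a carbonyl carbon in view, 3,4-dichlorophenyl in place of 3-iodophenyl on a carbonyl carbon. Going by the values given here, one measured step bears on this change, the modest 2.2-fold higher number from compound 1 to compound 2 (0.33 log units; beyond the scatter) at the same place. Two compounds set no trend, so in this assay a step no larger than that one is expected, possibly within the scatter. The direction is uncertain, with a slight lean to a lower number, towards compound 1 at 13000 nM as the only other reference. The expected change is a 1.6-fold lower number from compound 2 to compound 3 (0.19 log units; within the scatter) on present data. For compound 3 the estimated value is 18000 nM with 7000 nM as lower end and 45000 nM as upper end of the expected range.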

Compound 3, half-maximal inhibitory concentration: 28000 nM
Estimate against measurement, compound 3: 1.6-fold (0.19 log units) below; low and high end bracket the measured number.
By their numbers in this assay, from the lowest: compound 1; then compounds 2 and 3 (each within the scatter of the next).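

In this assay, 3,4-dichlorophenyl in place of 3-iodophenyl on the carbonyl carbon gives no change at the digits printed from compound 2 to compound 3 (within the scatter), so this exchange of one halogen-bearing phenyl for another, with one more heavy atom, does not separate the two compounds. Measured against the 2-fluorophenyl group, the same position gives a 2.2-fold higher number from compound 1 to compound 3 (0.33 log units; beyond the scatter), and compound 1 now stands apart from two compounds rather than one. Nothing at hand accounts for these numbers.

From the compounds shown here alone, all three compounds carry only halogens on this phenyl, so the effect of an amine, a carboxylic acid or a methoxy group there stays open. Going by these compounds alone, with compound 1 the only 2-fluorophenyl example, it also remains unknown whether its lower number reflects the fluorine itself or where the fluorine sits.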